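The compounds below may be only part of what the source reports. "The series", "measured", "known", "first", "only" and "open" are said of these compounds alone.

Compound 1 `CC(=O)c1c(Nc2ccc(F)cc2F)[nH]c2c(F)cc(F)cc2c1=O` is tested in an ADME assay on Vero cells (Chlorocebus sabaeus) for cytotoxicity; a lower number here means that less compound is tolerated, a higher number that more compound is tolerated. In this assay compound 1 gives only a limit of the assay, > 25000 nM. Compound 2 `CCCCNc1[nH]c2c(F)cc(F)cc2c(=O)c1C(C)=O` differs from it by butyl in place of 2,4-difluorophenyl on a nitrogen on an aromatic ring. In this assay compound 2 likewise gives only a limit of the assay, > 25000 nM. The step that the two limits leave unreadable from compound 1 to compound 2 therefore cannot be read in either direction. Where compound 2 stands is thus known only as a limit, and the limit of > 25000 nM in this assay, at which 2 of the 2 values shown sit, sums up everything the measured pair shows.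

Compound 3 `CC(=O)c1c(NCc2ccc(F)cc2F)[nH]c2c(F)cc(F)cc2c1=O` carries the change (2,4-difluorophenyl in place of propyl on a saturated chain carbon bound to a nitrogen on an aromatic ring). Within the data shown here, no measured step bears directly on this change: the one step available has no readable size, so neither a direction nor a magnitude can be carried over to it. Because the limit of > 25000 nM in this assay, at which 2 of the 2 values shown sit, shows both measured values sitting at the same limit, compound 3 is expected to sit there as well, with a step that the limit leaves unreadable from compound 2 to compound 3 expected to be none beyond the scatter. In this assay compound 3 is therefore estimated at 30000 nM, with a range from 12000 nM to 70000 nM.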

Compound 3, half-maximal cytotoxic concentration: > 25000 nM
Compound 3: only a limit was reported (the forecaster's own chance of this, stated with the estimate: 80%); the middle value does not contradict the limit.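

In this assay, among these compounds, compound 3 gives only a limit of the assay, > 25000 nM, so no step from compound 2 to compound 3 can be read. The compounds shown leave open at what concentration compound 1, compound 2 or compound 3 would become cytotoxic, and whether their differing groups change that, since all that is measured comes down to one point: the limit of > 25000 nM in this assay, at which 3 of the 3 values shown sit.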